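The source may report more compounds than this note shows. Statements on the series, on what has been measured and on what is new or still open speak of the compounds shown alone.

In an ADME assay on the whole organism (strain Sprague-Dawley) for pharmacokinetics, with Rattus norvegicus as the target, at a dose of 10 mg/kg by the oral route (on this read-out lower numbers stand for lower oral bioavailability and higher numbers for higher oral bioavailability), compound 1 `COc1nc2cccnc2n1-c1ccc(Nc2ccc(C)cn2)cc1` gives 28% and compound 2 `COc1nc2cccnc2n1-c1ccc(Nc2nc3ccccc3s2)cc1` gives 30% on the shared core. The two values lie within the scatter of each other, so compound 1 has a close neighbour and no clear rank. Within the data shown here, the only measured step is a number 2 percentage points higher from compound 1 to compound 2 (within the scatter) and it comes with 1,3-benzothiazol-2-yl in place of 5-methylpyridin-2-yl on a nitrogen on an aromatic ring.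

Compound 3 `CCCc1nc2cccnc2n1-c1ccc(Nc2ccc(C)cn2)cc1` keeps the 5-methylpyridin-2-yl of compound 1 and changes elsewhere: propyl in place of methoxy on an aromatic carbon gives propyl in place of methoxy on an aromatic carbon, between two ring nitrogen atoms. The measured step lies at another place and bears on this exchange only indirectly. Among the measured compounds shown here, no measured pair covers methoxy against propyl, so the data offer no direction and no step beyond the scatter can be foreseen in this assay with any confidence. The expected result is a number 2 percentage points higher from compound 1 to compound 3 (within the scatter) and this estimate carries wide uncertainty. For compound 3 the estimated value is 30% with an expected range from 12% to 55% in this read-out.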

Compound 3, oral bioavailability: 24%
The estimate for compound 3 lay 6 percentage points above the measured number; the range from low to high includes it.
By their numbers in this assay, from the lowest: compounds 3, 1 and 2 (each within the scatter of the next).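

In this assay, among these compounds, compound 3 gives this position its only measured pair: with propyl in place of methoxy on an aromatic carbon, between two ring nitrogen atoms, the result is a number 4 percentage points lower from compound 1 to compound 3 (within the scatter). Here a group with a hydrogen-bond acceptor gives way to one without, and oral bioavailability in this pair stays within the scatter, so the oxygen of methoxy is not shown to be needed at this place, nor does propyl show a gain or a loss. No measurement at hand offers a reason for this result.

The compounds shown leave open whether any other group at this position, such as an amine, a carboxylic acid or a chain longer than propyl, would move the number beyond the scatter. They also leave open whether propyl would give a similar result when 1,3-benzothiazol-2-yl stands in place of 5-methylpyridin-2-yl on the nitrogen on the aromatic ring.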